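This account rests on a few compounds, and the source may have more. Where it says the series, first, only, none or still open, it means among the compounds named here.

Measured compounds:
compound 1, `COc1ccc(C(=O)Nc2ccccc2Br)cc1OC1CCCC1`, 130 nM
compound 2, `COc1ccc(C(=O)Nc2ccccc2C(F)(F)F)cc1OC1CCCC1`, 3100 nM
compound 3, `COc1ccc(C(=O)Nc2ccccc2SC)cc1OC1CCCC1`, 1200 nM

The three measured compounds share one core and differ only in the group on the amide-type nitrogen. In an assay on isolated protein for inhibition of phosphodiesterase 4A (Sus scrofa) (a higher number here means a weaker inhibitor, a lower number a stronger inhibitor), compound 1 gives 130 nM, compound 2 gives 3100 nM and compound 3 gives 1200 nM. Compound 3 therefore stands second highest of the three numbers: the nearer step is a 2.6-fold lower number from compound 2 to compound 3 (0.41 log units; beyond the scatter), and the further step is a 9.2-fold higher number from compound 1 to compound 3 (0.97 log units; beyond the scatter).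

Compound 4, `COc1ccc(C(=O)Nc2c(Br)cncc2Br)cc1OC1CCCC1`, has not yet been measured. It differs from compound 3 by 3,5-dibromopyridin-4-yl in place of 2-(methylsulfanyl)phenyl on an amide-type nitrogen. The step that bears most directly on this change is a 9.2-fold higher number from compound 1 to compound 3 (0.97 log units; beyond the scatter), which was beyond the scatter and placed the bromo-bearing compound 1 at the lowest number. Compound 4 carries two bromines rather than a methylsulfanyl group, so a return toward the number of compound 1, or lower, is expected. Within the data shown here, no measured step covers the ring nitrogen, so the range is kept wide. The expected step is a 30-fold lower number from compound 3 to compound 4 (1.48 log units; beyond the scatter), and compound 4 is estimated at 40 nM, between 10 nM and 200 nM.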

Compound 4, half-maximal inhibitory concentration: 7 nM
Beside the measured number, compound 4's estimate is 5.7-fold (0.76 log units) above it; the whole stated range lies above it.
By their numbers in this assay, from the lowest: compound 4; then compound 1; then compound 3; then compound 2.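

In this assay, among these compounds, the replacement of 2-(methylsulfanyl)phenyl by 3,5-dibromopyridin-4-yl on the amide-type nitrogen gives a 170-fold lower number from compound 3 to compound 4 (2.23 log units; beyond the scatter), so this position tolerates an exchange of the whole aromatic group and can carry a far lower number than the earlier compounds reached. The second step, a 19-fold lower number from compound 1 to compound 4 (1.27 log units; beyond the scatter), shows that the number of 2-bromophenyl was not the floor for this position, and that a group with a ring nitrogen and two bromines goes beyond it. Nothing available here accounts for the size of either step.

The ring nitrogen and the second bromine enter together, so the compounds shown do not separate what each contributes. A pyridine ring carrying no bromine, a phenyl ring carrying two bromines, or chloro in place of bromo would each remain to be seen.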